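The source may report more compounds than this note shows. Statements on the series, on what has been measured and on what is new or still open speak of the compounds shown alone.

Measured values in a physicochemical assay for acid dissociation:
compound 1 `CCC(CC)c1ccc2c(NCCCNCc3cccc(OC)c3O)ccnc2c1`: 9.47
compound 2 `COc1cccc(CNCCCNc2ccnc3cc(-c4ccccc4)ccc23)c1O`: 9.47
compound 3 `COc1cccc(CNCCCNc2ccnc3cc(Oc4ccccc4)ccc23)c1O`: 9.28

Compound 3 gives the lowest of the three numbers, but the steps of a number 0.19 log units lower from compound 1 to compound 3 (within the scatter) and a number 0.19 log units lower from compound 2 to compound 3 (within the scatter) both stay inside the scatter, and no change at the digits printed from compound 1 to compound 2 (within the scatter) as well, so the three values cannot be told apart.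

Compound 4 `COc1cccc(CNCCCNc2ccnc3cc(Cc4ccc(F)cc4)ccc23)c1O` awaits measurement in this assay. The change from compound 3: 4-fluorobenzyl in place of phenoxy on an aromatic carbon. All three measured steps swap the group at the same aromatic carbon — pentan-3-yl, phenyl, phenoxy — and none moves the number beyond the scatter. On that basis no step beyond the scatter is expected here either, with a number 0.12 log units higher from compound 3 to compound 4 (within the scatter) the expected step.

Compound 4 is estimated at 9.4, with a range from 9.1 to 9.7.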

Compound 4, acid dissociation constant: 9.47
Beside the measured number, compound 4's estimate is 0.07 log units below it, and the stated range covers the measured number.
By their numbers in this assay, from the lowest: compounds 3, 1, 2 and 4 (each within the scatter of the next).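

In this assay the aromatic carbon para to a fused ring also takes 4-fluorobenzyl without a step beyond the scatter, giving a number 0.19 log units higher from compound 3 to compound 4 (within the scatter) and no change at the digits printed from compound 2 to compound 4 (within the scatter) and also no change at the digits printed from compound 1 to compound 4 (within the scatter) in this series. Four different groups at this place now leave the values indistinguishable, including the first with fluorine. Nothing available here accounts for this flat result.

From the compounds shown here alone, whether an amine or a carboxylic acid at this carbon would move the number beyond the scatter remains open. All four compounds share the rest of the core, so changes elsewhere cannot be judged.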